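Adding ethyl to an amide nitrogen in an inactive series

A few compounds are considered here, and "the series" means these few. Any claim that something is new, unique, unknown or untested is made for them only; others in the source may bear on it.

Compound 1 `O=C(CC(CC(=O)NC1Cc2ccccc2C1)c1ccccc1)NCCN1CCCCC1` is the starting point. In a functional assay on L02 cells (Homo sapiens) for inhibition (a higher number here means a weaker inhibitor, a lower number a stronger inhibitor), compound 1 gives > 100000 nM, which is a limit of the assay and not a number. Compound 2 `CCN(CC)CCNC(=O)CC(CC(=O)NC1Cc2ccccc2C1)c1ccccc1` gives > 100000 nM, also a limit. Compound 3 `Cc1ccc(C(CC(=O)NCCN2CCCCC2)CC(=O)NC2Cc3ccccc3C2)cc1` gives > 100000 nM, again a limit. All three compounds therefore share (the limit of > 100000 nM in this assay, at which 3 of the 3 values shown sit). Two changes elsewhere in the molecule offer only a step that the two limits leave unreadable from compound 1 to compound 2 and a step that the two limits leave unreadable from compound 1 to compound 3. Compound 4 `CCN(C(=O)CC(CC(=O)NCCN1CCCCC1)c1ccccc1)C1Cc2ccccc2C1` differs from compound 1 at another place: ethyl in place of hydrogen on an amide-type nitrogen. Neither measured step sizes this change, so no clear direction can be expected. The expected result is a number no higher from compound 1 to compound 4 (the limit leaves the size open). Compound 4 is estimated at 100000 nM, with an expected range of 40000 nM to 200000 nM.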

Compound 4, half-maximal inhibitory concentration: > 100000 nM
Compound 4 gave a limit, no number; the forecaster's own chance of this, stated with the estimate: 85%; the middle value sits exactly at the limit.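

Compound 4 gives > 100000 nM, a limit of the assay and not a number. Compound 1 gives > 100000 nM, also a limit, so no step can be read for the ethyl change. How strongly any of these compounds inhibits in this assay stays open, because all of them sit at the same limit: the limit of > 100000 nM in this assay, at which 4 of the 4 values shown sit.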